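Notes on the step from compound 3 to compound 4

This account rests on a few compounds, and the source may have more. Where it says the series, first, only, none or still open, it means among the compounds named here.

Three compounds of this series have numbers in an assay on T-REx-293 cells for inhibition of potassium channel subfamily T member 1 (Homo sapiens), read by patch clamp; on this read-out higher numbers stand for weaker inhibition and lower numbers for stronger inhibition. Compound 1 `Cc1cccc(-c2noc([C@@H](C)NC(=O)c3cc(C4CC4)nn3C)n2)c1` gives 3310 nM. Compound 2 `C[C@@H](c1nc(-c2cccc(F)c2)no1)N(C)C(=O)c1cc(C(F)(F)F)nn1C` gives 6490 nM in this assay. Compound 3 `Cc1ccnc(-c2noc([C@H](C)NC(=O)c3cc(C(F)(F)F)nn3C)n2)c1` gives 4470 nM in this assay, the second highest of the three numbers; its nearest neighbour is compound 1 and its furthest is compound 2, and both gaps lie within the scatter, so no order among the three can be read from them. Compound 4 `C[C@H](NC(=O)c1cc(C(F)(F)F)nn1C)c1nc(-c2ccnc(C3CC3)c2)no1` is not yet measured. It differs from compound 3 in one place: 2-cyclopropylpyridin-4-yl in place of 4-methylpyridin-2-yl on an aromatic carbon. Among the measured compounds shown here, no step between measured compounds that differ in one place is available, so the expected size of this step rests on the spread of the three numbers alone. The step is expected to be a 1.3-fold lower number from compound 3 to compound 4 (0.11 log units; within the scatter), no more than the scatter in either direction. Compound 4 is estimated at 3500 nM, with a range from 1200 nM to 10000 nM.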

Compound 4, half-maximal inhibitory concentration: 16 nM
Estimate against measurement, compound 4: 220-fold (2.34 log units) above; measured number below the stated range.
By their numbers in this assay, from the lowest: compound 4; then compounds 1, 3 and 2 (each within the scatter of the next).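

Among the compounds shown here, on this assay this aromatic carbon of the five-membered ring, between two ring nitrogen atoms, proves highly sensitive to the group it carries: 2-cyclopropylpyridin-4-yl in place of 4-methylpyridin-2-yl gives a 280-fold lower number from compound 3 to compound 4 (2.45 log units; beyond the scatter) and no earlier compound hinted at a step of this size. The change moves the ring attachment and replaces methyl with cyclopropyl at once, so the step belongs to both together. Nothing at hand explains its size.

As far as these compounds go, whether the cyclopropyl group or the attachment carries the step stays open; 2-methylpyridin-4-yl on the same carbon would separate the two. Also open, from the compounds shown here alone, is whether cyclobutyl in place of cyclopropyl would hold the step.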